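Chloro substitution on a urea-linked analogue

This account rests on a few compounds, and the source may have more. Where it says the series, first, only, none or still open, it means among the compounds named here.

Measured so far in a functional assay on MDA-MB-231 cells (Homo sapiens) for antiproliferative activity, read by MTT assay, with a stated time of 72 h; a higher number here means a weaker inhibitor, a lower number a stronger inhibitor:
Compound 1 `CC(=O)Nc1ccc(S(=O)(=O)Nc2cccc(-c3nc(-c4ccc(NC(=O)c5cccnc5)cc4Cl)no3)c2)cc1` gives 2500 nM.
Compound 2 `CC(=O)Nc1ccc(S(=O)(=O)Nc2cccc(-c3nc(-c4ccc(NC(=O)c5cccnc5)cc4)no3)c2)cc1` gives 5200 nM.
Compound 3 `O=C(Nc1ccccc1)Nc1cccc(-c2nc(-c3ccc(NC(=O)c4cccnc4)cc3Cl)no2)c1` gives only a limit, > 10000 nM.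

Compounds 2 and 1 differ by chloro in place of hydrogen on an aromatic carbon, and that step gave a 2.1-fold lower number from compound 2 to compound 1 (0.32 log units; beyond the scatter). The core of compound 3 is not broken down against compound 2 here. Compound 4 `O=C(Nc1ccc(Cl)cc1)Nc1cccc(-c2nc(-c3ccc(NC(=O)c4cccnc4)cc3Cl)no2)c1` differs from compound 3 by chloro in place of hydrogen on an aromatic carbon; the surroundings differ, ortho to a large group and meta to a ((pyridin-3-yl)carbonyl)amino group in the earlier pair, para to a large group now, so this is the same kind of change rather than the same one. Because compound 3 sits at the limit of > 10000 nM in this assay, at which 1 of the 3 values shown sits, the earlier step is a weak guide; compound 4 is expected to move by about an at least 1.2-fold lower number from compound 3 to compound 4 (0.09 log units; that floor lies within the scatter). The estimate for compound 4 in this assay is 8000 nM.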

Compound 4, half-maximal inhibitory concentration: > 10000 nM
Compound 4: only a limit was reported; the forecaster's own chance of this, stated with the estimate: 55%; middle value at least 1.2-fold (0.09 log units) away from the limit.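

Compound 3 and compound 4 are both reported only as limits, so no step between them can be read: the limit of > 10000 nM in this assay, at which 2 of the 4 values shown sit.

On these data alone, whether going from phenyl to 4-chlorophenyl changes the activity of this pair at all remains open.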